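The source may report more compounds than this note shows. Statements on the series, on what has been measured and on what is new or still open speak of the compounds shown alone.

Measured compounds:
compound 1 `CCCN(CCC)c1nc(C(C)(C)C)ccc1CNC(=O)C(C)c1ccc(NS(C)(=O)=O)c(F)c1`, an assay on cells for antagonist activity at transient receptor potential cation channel subfamily V member 1 (Homo sapiens), read by FLIPR and calcium flux, with a stated time of 6 min (a higher number here means a weaker inhibitor, a lower number a stronger inhibitor), 2.5 nM
compound 2 `CCCCSc1nc(C(C)(C)C)ccc1CNC(=O)C(C)c1ccc(NS(C)(=O)=O)c(F)c1`, 3.2 nM

Within the data shown here, of the two numbers measured, compound 2 and compound 1 lie inside the usual scatter of each other, the only measured step being a 1.3-fold higher number from compound 1 to compound 2 (0.11 log units; within the scatter). That step exchanged one substituent on the same aromatic carbon of the shared core for another, and left the inhibition constant essentially where it was.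

Compound 3 `CC(C(=O)NCc1ccc(C(C)(C)C)nc1C1CCCCC1)c1ccc(NS(C)(=O)=O)c(F)c1` takes the same position on the core of compound 2 and changes it once more: cyclohexyl in place of butylsulfanyl on an aromatic carbon. Among the measured compounds shown here, the one measured step that bears on this position is the step from compound 1 to compound 2, which was within the scatter. For the measured compounds named here, no measured step exchanges a chain for a ring at this carbon, so the size of the coming step is not covered by data; the only guidance is that the previous exchange at this position was tolerated.

The expectation is therefore a step from compound 2 to compound 3 of a 1.3-fold higher number from compound 2 to compound 3 (0.10 log units; within the scatter), probably within the scatter. For compound 3 in this assay the estimate is 4 nM, with a range from 1.5 nM to 12 nM.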

Compound 3, inhibition constant: 3.1 nM
Compound 3: middle estimate off by 1.3-fold (0.11 log units), on the high side, within the range that was stated.
By their numbers in this assay, from the lowest: compounds 1, 3 and 2 (each within the scatter of the next).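

In this assay, the exchange of a chain for a ring on this aromatic carbon next to the ring nitrogen gives a 1.0-fold lower number from compound 2 to compound 3 (0.01 log units; within the scatter), and the comparison with the amine-bearing substituent gives a 1.2-fold higher number from compound 1 to compound 3 (0.09 log units; within the scatter). Dipropylamino, butylsulfanyl and cyclohexyl therefore cannot be told apart here, so across these three compounds the number holds with an open chain or a six-membered non-aromatic ring of carbon only, and with a sulfur atom and its hydrogen-bond acceptor replaced by carbon alone. Nothing available explains why these three substituents read alike.

Still open, from the compounds shown here alone, is whether this carbon accepts a much smaller group such as methyl, a flat ring such as phenyl, or a group such as a primary amine or a carboxylic acid, any of which would test the limits of what has so far looked like a freely exchangeable position. Also open, going by these compounds, is whether the same exchanges read alike when the tert-butyl group meta to this carbon is replaced by another group, such as trifluoromethyl.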